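This account rests on a few compounds, and the source may have more. Where it says the series, first, only, none or still open, it means among the compounds named here.

Measured in a functional assay on the whole organism with Rattus norvegicus as the target; on this read-out higher numbers stand for an effect only at larger amounts of compound and lower numbers for an effect already at smaller amounts:
- Compound 1 `CCOCCOC(=O)C(=O)Nc1nc(-c2conc2C)cs1`: > 100 mg/kg (a limit of the assay, not a number)
- Compound 2 `CCOCCOC(=O)C(=O)Nc1nc(-c2cc(-c3ccccc3)on2)cs1`: 13 mg/kg
- Compound 3 `CCOCCOC(=O)C(=O)Nc1nc(-c2cc(CO)on2)cs1`: 14 mg/kg

Compound 3 stands with compound 2, and the two lie within the scatter of each other: a 1.1-fold higher number from compound 2 to compound 3 (0.03 log units; within the scatter). Compound 1 offers only a limit for comparison.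

The next structure, compound 4 `O=C(O)C(=O)Nc1nc(-c2cc(CO)on2)cs1`, keeps the core and the hydroxymethyl group of compound 3. It carries hydrogen in place of 2-ethoxyethyl on an oxygen next to a carbonyl group.

Neither measured step touches that place. Both exchange a group on an aromatic carbon, and all three measured compounds retain the 2-ethoxyethyl group. The first step shows a clear move in this assay, an at least 7.1-fold lower number from compound 1 to compound 3 (0.85 log units; beyond the scatter), while the second, a 1.1-fold higher number from compound 2 to compound 3 (0.03 log units; within the scatter), shows none beyond the scatter. Neither can be carried over to the new change, so the size of the step rests on little. A modest move towards a higher number is expected, with a wide margin on either side.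

The expected step runs a 1.8-fold higher number from compound 3 to compound 4 (0.25 log units; within the scatter). Compound 4 is estimated at 25 mg/kg, with an expected range of 5 mg/kg to 100 mg/kg.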

Compound 4, dose for half-maximal effect: > 30 mg/kg
Compound 4: only a limit was reported; the forecaster's own chance of this, stated with the estimate: 20%; middle value at least 1.2-fold (0.07 log units) from the limit.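

The change of 2-ethoxyethyl to hydrogen on an oxygen next to a carbonyl group, which turns 2-ethoxyethoxy into hydroxy, is the first change at this place among the compounds shown, and in this assay it gives an at least 2.1-fold higher number from compound 3 to compound 4 (0.33 log units; beyond the scatter). Going by these compounds alone, the earlier steps exchanged groups on an aromatic carbon only, so this pair is the first sign that the outcome in this assay also depends on what sits on this oxygen, and that hydrogen there does not keep the level of compound 3. For compound 4 the reading is a limit and not a number, so the full size of the step stays unknown: the limit of > 30 mg/kg in this assay, at which 1 of the 4 values shown sits.

The compounds shown leave open whether a smaller chain such as ethyl, or a longer chain, on this oxygen would stay level with compound 3 or move away from it, and whether an amine in place of the 2-ethoxyethoxy group would do the same. As far as these compounds go, the change is also seen on a single pair, so it remains open whether hydrogen on this oxygen acts alike with phenyl on the aromatic carbon, as in compound 2.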